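This account rests on a few compounds, and the source may have more. Where it says the series, first, only, none or still open, it means among the compounds named here.

For the measured compounds named here, compound 2, drawn as `CC1(C)C[C@@H](Nc2cc(NCc3cnccc3C(F)(F)F)ncc2C#N)CC[C@H]1O`, gives 2400 nM in an assay on isolated protein for inhibition of protein kinase C delta type (Homo sapiens), read by TR-FRET, with a stated time of 2 h (on this read-out lower numbers stand for stronger inhibition and higher numbers for weaker inhibition), and it carries the only numerical value among the two compounds measured. Compound 1, drawn as `N#Cc1cnc(NCc2cnccc2C(F)(F)F)cc1N[C@H]1C[C@H](O)C1`, is reported in this assay only as a limit, > 10000 nM. Going by the values given here, the one measured step, an at least 4.1-fold lower number from compound 1 to compound 2 (0.61 log units; beyond the scatter), is thus bounded on one side by the limit of > 10000 nM in this assay, at which 1 of the 2 values shown sits.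

Compound 3, drawn as `CC1(C)C[C@@H](Nc2cc(NCc3cnccc3C(F)(F)F)ncc2C#N)CC[C@@H]1O`, is the unmeasured partner of compound 2. The change is the two compounds have the same atoms and bonds and differ only in configuration as drawn: 1 of 2 stereo elements differ; a stereocentre at a saturated ring carbon is drawn R in compound 2 and S in compound 3; the hydroxyl-bearing ring carbon is simply inverted, so the same atoms and bonds are kept and only the drawn configuration differs.

Among the compounds with values here, no measured step bears directly on this change: the step from compound 1 to compound 2 swaps one saturated ring for another rather than inverting a single centre, so it gives no direction for a configurational flip. An inversion at a hydroxyl-bearing carbon can shift affinity in either direction, and with nothing else to go on a step near or modestly beyond the scatter, toward a weaker number, is expected, as a 1.9-fold higher number from compound 2 to compound 3 (0.27 log units; within the scatter). Compound 3 is therefore estimated at 4500 nM, with a range from 1500 nM to 15000 nM.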

Compound 3, half-maximal inhibitory concentration: 2400 nM
Beside the measured number, compound 3's estimate is 1.9-fold (0.27 log units) above it; the range from low to high includes it.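

In this assay, inverting the hydroxyl-bearing ring carbon of the 4-hydroxy-3,3-dimethylcyclohexyl group does not separate the two isomers, with no change at the digits printed from compound 2 to compound 3 (within the scatter), and the comparison is a clean one: the fact that compounds 2 and 3 differ only in the configuration as drawn. For the compounds shown here, the earlier compounds could not show this, since their only step exchanged one saturated ring for another; that exchange now reads the same way with the hydroxyl-bearing carbon in the other configuration, with an at least 4.1-fold lower number from compound 1 to compound 3 (0.61 log units; beyond the scatter). From the compounds shown here alone, compound 1 stands only as a limit, so the size of that step stays open on one side: the limit of > 10000 nM in this assay, at which 1 of the 3 values shown sits.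

What the compounds shown leave open is whether the hydroxyl group matters at all in this place, since every compound carries one, and a methoxy group, an amine or a carboxylic acid on the same ring carbon would address that. They also leave open what the two ring methyl groups contribute, and whether the other stereocentre of the ring is as indifferent to inversion as the hydroxyl-bearing carbon proves to be in this pair.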